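Adding propyl to the side chain of compound 3

This account rests on a few compounds, and the source may have more. Where it says the series, first, only, none or still open, it means among the compounds named here.

compound 1 `CCC(CCO)n1cnc2c(Cl)nc(F)nc21`: 18900 nM
compound 2 `CCCCCCC(CCO)n1cnc2c(Cl)ncnc21`: 11900 nM
compound 3 `CCCCCCC(CCO)n1c(Br)nc2c(Cl)ncnc21`: 16100 nM

In a functional assay on HCT-116 cells (Homo sapiens) for antiproliferative activity, read by MTT assay, with a stated time of 48 h (on this read-out lower numbers stand for stronger inhibition and higher numbers for weaker inhibition), the three measured compounds sit close together. Compound 3 lies within the scatter of both compound 1 and compound 2, so it has no clear rank and is best read as part of a flat group.

Compound 4 `CCCCCCCCCC(CCO)n1c(Br)nc2c(Cl)ncnc21` differs from compound 3 only on the side chain: propyl in place of hydrogen on a saturated chain carbon, seven bonds along the chain from an aromatic nitrogen. The core and its bromo group stay as they are.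

Within the data shown here, no measured step changes this chain alone. Among the measured compounds shown here, the one step available, a 1.4-fold higher number from compound 2 to compound 3 (0.13 log units; within the scatter), is a bromo swap on an aromatic carbon, so it bears on the new change only indirectly. Compound 1 has a shorter chain than compound 2 but also differs elsewhere, so that pair is no clean comparison, although their two values lie close. The data therefore give no reason to expect a step beyond the scatter in this assay, and they favour no direction. The expected change is a 1.2-fold lower number from compound 3 to compound 4 (0.06 log units; within the scatter). For compound 4 the estimated value is 14000 nM, with an expected range from 6000 nM to 30000 nM.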

Compound 4, half-maximal inhibitory concentration: 26900 nM
Estimate against measurement, compound 4: 1.9-fold (0.28 log units) below, and the stated range covers the measured number.
By their numbers in this assay, from the lowest: compounds 2, 3, 1 and 4 (each within the scatter of the next, the first and the last beyond it).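

Among the compounds shown, this is the only step that changes the side chain alone, and it gives a 1.7-fold higher number from compound 3 to compound 4 (0.22 log units; within the scatter) in this assay. Placing propyl on a saturated chain carbon, seven bonds along the chain from an aromatic nitrogen, therefore adds three carbons without moving the reading beyond the usual scatter of repeat measurements, so this single step shows no clear gain or loss from the longer chain. Nothing measured here offers an explanation for that outcome, so the result describes what happened at this position but not why.

The compounds shown leave open whether this position would respond differently to a much longer chain, a phenyl ring, or an amine or a carboxylic acid placed on the chain, since each would change more than the length of a plain carbon chain. They also leave open whether the same propyl addition would read the same way on a core without the bromo group, which would show whether the two changes act independently.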